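Cyclopentyl for cyclopropyl on the amide-type nitrogen

The compounds below may be only part of what the source reports. "The series", "measured", "known", "first", "only" and "open" are said of these compounds alone.

In an ADME assay on MDBK cells (Bos taurus) for cytotoxicity, read by MTT assay (a higher number here means that more compound is tolerated, a lower number that less compound is tolerated), compound 3 `CC(C)(C)C(=O)N(CCCCCCN1C[C@H](O)[C@@H](O)[C@H](O)[C@H]1CO)C1CC1` is reported only as a limit, > 500000 nM. Compound 1 `CC(C)(C)C(=O)N(CCCCCCN1C[C@H](O)[C@@H](O)[C@H](O)[C@H]1CO)c1ccc(F)cc1F` is likewise reported only as a limit in this assay, > 500000 nM. Compound 2 `CC(C)(C)C(=O)N(CCCCCCN1C[C@H](O)[C@@H](O)[C@H](O)[C@H]1CO)c1cc(F)ccc1F` also stands at a limit in this assay, > 500000 nM. Within the data shown here, as all three values sit at the limit of > 500000 nM in this assay, at which 3 of the 3 values shown sit, the steps a step that the two limits leave unreadable from compound 1 to compound 2, a step that the two limits leave unreadable from compound 1 to compound 3 and a step that the two limits leave unreadable from compound 2 to compound 3 cannot be read in size or direction; what they show is only that exchanging 2,4-difluorophenyl, 2,5-difluorophenyl or cyclopropyl on the amide-type nitrogen has left no compound measurable below the limit.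

Compound 4 `CC(C)(C)C(=O)N(CCCCCCN1C[C@H](O)[C@@H](O)[C@H](O)[C@H]1CO)C1CCCC1` carries the change (cyclopentyl in place of cyclopropyl on an amide-type nitrogen). Among the measured compounds shown here, none of the measured steps covers this particular exchange, and none of them is readable, so no step size can be carried over. The three limits together give no sign that any variation at this position brings tolerance down into the measurable range.

Compound 4 is therefore expected to reach the limit as well, with an estimate of 500000 nM and a range from 250000 nM to 2000000 nM. The step this estimate implies is a number no higher from compound 3 to compound 4 (the limit leaves the size open), expected to be none beyond the scatter.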

Compound 4, half-maximal cytotoxic concentration: > 500000 nM
Compound 4 ended at the assay's limit; the forecaster's own chance of this, stated with the estimate: 85%; the middle value sits exactly at the limit.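

In this assay compound 4 is reported only as a limit, > 500000 nM. Its steps from compound 1, compound 2 and compound 3 therefore cannot be read in size or direction: the limit of > 500000 nM in this assay, at which 4 of the 4 values shown sit.

The compounds shown leave open how much of each compound is tolerated, and whether any group on the amide-type nitrogen gives a value inside the measurable range.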